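Permeability notes on compound 4 and its measured neighbours

The source may hold more compounds than are shown below. What is called first, only, known or untested is meant among the compounds shown, and "the series" means these compounds.

Compound 2 `CC(C)(C)C[C@@H](O)C(=O)N1C[C@@H]2C[C@@H]2[C@H]1C(=O)NCc1cc(Cl)ccc1-n1cnnn1` and compound 1 `CC(C)(C)[C@@H](O)C(=O)N1C[C@@H]2C[C@@H]2[C@H]1C(=O)NCc1cc(Cl)ccc1-n1cnnn1` differ by tert-butyl in place of neopentyl on a saturated chain carbon bound to a carbonyl carbon and an oxygen on a saturated carbon. In an ADME assay on Caco-2 cells (Homo sapiens) for permeability, read by LC-MS, in the apical to basolateral direction, with a stated time of 60 min, at pH 6.5 (on this read-out lower numbers stand for lower permeability and higher numbers for higher permeability), compound 2 gives 25 10^-6 cm/s, and compound 1 gives 17 10^-6 cm/s, a step of a 1.5-fold lower number from compound 2 to compound 1 (0.17 log units; within the scatter). Compound 3 `CC(C)(C)C[C@@H](O)C(=O)N1[C@@H]2C[C@@H]2C[C@H]1C(=O)NCc1cc(Cl)ccc1-n1cnnn1` has the same atoms as compound 2 joined differently; the difference between the two cores is not broken down here. In this assay compound 3 gives 24 10^-6 cm/s, which sits next to the number for compound 2 within the scatter. Compound 4 `CC(C)(C)[C@@H](O)C(=O)N1[C@@H]2C[C@@H]2C[C@H]1C(=O)NCc1cc(Cl)ccc1-n1cnnn1` is not yet measured and differs from compound 3 by tert-butyl in place of neopentyl on a saturated chain carbon bound to a carbonyl carbon and an oxygen on a saturated carbon, the same change made from compound 2 to compound 1, at the same place. For compound 4 the expected step in this assay is a 1.4-fold lower number from compound 3 to compound 4 (0.15 log units; within the scatter), set beside the measured 1.5-fold lower number from compound 2 to compound 1 (0.17 log units; within the scatter), and it rests on that one earlier step only. Compound 4 is therefore estimated at 17 10^-6 cm/s, with a likely range from 10 10^-6 cm/s to 28 10^-6 cm/s.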

Compound 4, apparent permeability: 34 10^-6 cm/s
Estimate against measurement, compound 4: 2.0-fold (0.30 log units) below; measured number above the stated range.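

Tert-butyl in place of neopentyl on the core of compound 3 gives a 1.4-fold higher number from compound 3 to compound 4 (0.15 log units; within the scatter) in this assay, so on each core this change stays within the usual scatter. The two steps point in opposite directions on paper but cannot be told apart: the same change on two cores in this assay, a 1.5-fold lower number (0.17 log units; within the scatter) from compound 2 to compound 1 and a 1.4-fold higher number (0.15 log units; within the scatter) from compound 3 to compound 4, 2.1-fold (0.32 log units) apart, within the scatter of two such steps. This shows no measurable dependence of the change on the core, but with one pair per core and every step within the scatter, it does not show that the change carries over with a fixed size or direction.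

Only tert-butyl and neopentyl appear at this place on the two cores. Going by these compounds, how a longer chain, an amine or a carboxylic acid there would read in this assay remains open.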